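Adding a hydroxy to the methoxyphenyl arm of a nucleoside

The compounds below may be only part of what the source reports. "The series", "measured", "known", "first", "only" and "open" are said of these compounds alone.

Of the compounds shown here, three sharing one nucleoside core have been measured. In a functional assay on HL-60 cells (Homo sapiens) for antiproliferative activity, with a stated time of 72 h (on this read-out higher numbers stand for weaker inhibition and lower numbers for stronger inhibition), compound 1 `OC[C@H]1O[C@@H](n2cnc3c(NCc4ccccc4F)ncnc32)[C@H](O)[C@@H]1O` gives 3200 nM, compound 2 `OC[C@H]1O[C@@H](n2cnc3c(NCc4cccc(Br)c4)ncnc32)[C@H](O)[C@@H]1O` gives 8000 nM, and compound 3 `COc1cccc(CNc2ncnc3c2ncn3[C@@H]2O[C@H](CO)[C@@H](O)[C@H]2O)c1` gives 4900 nM. Compound 3 stands second highest of the three numbers; its nearest neighbour is compound 1, its furthest compound 2, and both gaps lie within the scatter. Across the set only the swap a 2.5-fold higher number from compound 1 to compound 2 (0.40 log units; beyond the scatter) exceeds the scatter, while a 1.5-fold higher number from compound 1 to compound 3 (0.19 log units; within the scatter) and a 1.6-fold lower number from compound 2 to compound 3 (0.21 log units; within the scatter) do not.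

Compound 4 `COc1cccc(CNc2ncnc3c2ncn3[C@@H]2O[C@H](CO)[C@@H](O)[C@H]2O)c1O` differs from compound 3 by hydroxy in place of hydrogen on an aromatic carbon, so that the 3-methoxyphenyl becomes 2-hydroxy-3-methoxyphenyl. Among the measured compounds shown here, no measured step introduces a hydroxy; the closest analogy is the substituent exchange on the same ring in a 1.6-fold lower number from compound 2 to compound 3 (0.21 log units; within the scatter), which stayed within the scatter, and the two changes involving compound 1 were at most modest. For the measured compounds named here, nothing among the measured compounds therefore points to a shift beyond the scatter in either direction.

On this basis, compound 4 is expected to give about 5000 nM in this assay, with a plausible range from 1800 nM to 14000 nM, corresponding to an estimated step of a 1.0-fold higher number from compound 3 to compound 4 (0.01 log units; within the scatter).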

Compound 4, half-maximal inhibitory concentration: 150 nM
Beside the measured number, compound 4's estimate is 33-fold (1.52 log units) above it; measured number outside the range, below it.
By their numbers in this assay, from the lowest: compound 4; then compounds 1, 3 and 2 (each within the scatter of the next, the first and the last beyond it).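

In this assay, a hydroxy placed on the aromatic carbon ortho to a large group and ortho to a methoxy group gives a large change, a 33-fold lower number from compound 3 to compound 4 (1.51 log units; beyond the scatter), whereas the exchanges among the three singly substituted arms reached at most a modest step (a 2.5-fold higher number from compound 1 to compound 2 (0.40 log units; beyond the scatter)). The 2-hydroxy-3-methoxyphenyl arm also separates clearly from the 3-bromophenyl arm, a 53-fold lower number from compound 2 to compound 4 (1.73 log units; beyond the scatter), and from the 2-fluorophenyl arm, a 21-fold lower number from compound 1 to compound 4 (1.33 log units; beyond the scatter), so among these four compounds, compound 4 alone has steps beyond the scatter to all the others, and a single added oxygen on this ring accounts for far more of the spread than any other change shown. Nothing available here explains why this hydroxy has so large an effect on the number.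

The compounds shown do not tell whether the hydroxy would give the same gain on its own, on a phenyl arm without the methoxy, or whether an amine or a carboxylic acid at that place would do the same. A second methoxy at that place would show whether the hydroxy hydrogen matters or the added oxygen alone is enough.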